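The source may hold more compounds than are shown below. What is called first, only, known or untested is meant among the compounds shown, and "the series" means these compounds.

Measured compounds:
- compound 1, `Cc1cc(C)cc(-c2c(O)nc3cc(Cl)c(NC(=O)c4cnccn4)cc3c2OCCC2CCCCN2)c1`: 1.8 nM
- compound 2, `CC(=O)OCc1cc(C)cc(-c2c(O)nc3cc(Cl)c([N+](=O)[O-])cc3c2OCCC2CCCCN2)c1`: 45 nM

In a functional assay on cells (Pituitary gland cell) for antagonist activity at Gonadotropin-releasing hormone receptor (Rattus norvegicus) (a lower number here means a stronger inhibitor, a higher number a weaker inhibitor), compound 1 gives 1.8 nM, the lowest of the two numbers. Compound 2 gives 45 nM, a higher number that lies beyond the scatter. Going by the values given here, no step between these two compounds is counted here.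

Compound 3, `Cc1cc(C)cc(-c2c(O)nc3cc(Cl)c(NC(=O)Nc4cccnc4)cc3c2OCCC2CCCCN2)c1`, keeps the core of compound 1 and differs from it in one place: (pyridin-3-yl)amino in place of pyrazin-2-yl on a carbonyl carbon. No comparable change has been measured in this set, so the step from compound 1 to compound 3 is expected to be small, with a slight move toward a higher number, a 1.7-fold higher number from compound 1 to compound 3 (0.22 log units; within the scatter). In this assay compound 3 is estimated at 3 nM, within the range 0.8 nM to 12 nM.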

Compound 3, half-maximal inhibitory concentration: 20 nM
Compound 3: the middle estimate sits 6.7-fold (0.82 log units) below what was measured, and the stated range ends below it.
By their numbers in this assay, from the lowest: compound 1; then compound 3; then compound 2.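

In this assay, going by these compounds alone, the group on the carbonyl carbon proves sensitive: (pyridin-3-yl)amino in place of pyrazin-2-yl gives an 11-fold higher number from compound 1 to compound 3 (1.05 log units; beyond the scatter) in the first single-place comparison of the set. The group held on this carbonyl carbon therefore matters to the inhibition measured here. No measured evidence bears on why the step is this large. The change swaps the ring and adds an amino link at once, so the compounds shown leave open which part carries the step. A (pyrazin-2-yl)amino group on the same carbonyl carbon would separate the two.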